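Methyl for Fluoro on the Aryl Ring of an Indole Acid

The compounds below may be only part of what the source reports. "The series", "measured", "known", "first", "only" and "open" are said of these compounds alone.

Compound 1 `O=C(O)CCc1ccc2[nH]c(-c3ccc(Cl)cc3Cl)cc2c1` gives 20.6 nM in a functional assay on CHO cells for agonist activity at Free fatty acid receptor 1 (Homo sapiens), read by a luciferase reporter, with a stated time of 24 h; a lower number here means that less compound is needed, a higher number that more compound is needed for the effect. Compound 2 `O=C(O)CCc1ccc2[nH]c(-c3ccc(Cl)cc3F)cc2c1` differs by fluoro in place of chloro on an aromatic carbon. In this assay, for the measured compounds named here, compound 2 reaches only a limit, > 25 nM, and no number is known; the single measured step, an at least 1.2-fold higher number from compound 1 to compound 2 (0.08 log units; that floor lies within the scatter), is therefore itself only a floor, and compound 2 sits at the limit of > 25 nM in this assay, at which 1 of the 2 values shown sits. Compound 3 `Cc1cc(Cl)ccc1-c1cc2cc(CCC(=O)O)ccc2[nH]1` carries methyl in place of fluoro on an aromatic carbon. Going by the values given here, no measured step involves a methyl group, so the only guide is that compound 1, with chloro at this position, gave 20.6 nM. Compound 2, with fluoro, gives only a limit. Compound 3 is expected to land near compound 1, and the estimated step is a number no higher from compound 2 to compound 3 (the limit leaves the size open). For compound 3 the estimated value in this assay is 25 nM, within 8 nM to 80 nM.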

Compound 3, half-maximal effective concentration: 0.25 nM
Compound 3: middle estimate off by 100-fold (2.00 log units), on the high side; measured number below the stated range.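

The earlier compounds shown here held only two halogens at this position, an aromatic carbon ortho to a large group, and did not show how far a change there could reach; methyl in place of chloro gives an 82-fold lower number from compound 1 to compound 3 (1.92 log units; beyond the scatter). Methyl in place of fluoro gives an at least 100-fold lower number from compound 2 to compound 3 (2.00 log units; beyond the scatter), so in this assay the position responds strongly to methyl in place of either halogen. The second of these steps is only a floor, since compound 2 stands at a limit: the limit of > 25 nM in this assay, at which 1 of the 3 values shown sits.

The compounds shown leave open whether a larger carbon group such as ethyl, or a trifluoromethyl or methoxy group, would match methyl here. They also leave open whether a methyl group on another carbon of this ring would give a step of similar size.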